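The compounds below may be only part of what the source reports. "The series", "measured", "known", "first", "only" and "open" are said of these compounds alone.

Compound 1 `COc1cccc(-n2cc3nc(-c4cccnc4C)n(C[C@H]4CCCN(CC5CCCCO5)C4)c(=O)c3n2)c1` belongs to a set of three measured in an assay on HEK293 cells for displacement of a labelled ligand from growth hormone secretagogue receptor type 1 (Homo sapiens), with a stated time of 60 min (a higher number here means a weaker inhibitor, a lower number a stronger inhibitor), where compound 1 gives 120 nM. That is the highest of the three numbers: compound 2 `COc1ccc(-n2cc3nc(-c4ccccc4C)n(CC4CCCN(C(C)C)C4)c(=O)c3n2)cc1` gives 7.3 nM, and compound 3 `Cc1ncccc1-c1nc2cn(-c3cccc(OC(C)C)c3)nc2c(=O)n1C[C@H]1CCCN(C[C@H]2CCCO2)C1` gives 11 nM, both clearly lower, beyond the scatter of repeated runs. Neither differs from compound 1 in a single place, so the two values are all that can be read from them. Compound 4 `COc1cccc(-n2cc3nc(-c4cccnc4C)n(C[C@H]4CCCN(CC5CCOC5)C4)c(=O)c3n2)c1` differs from compound 1 only by oxolan-3-yl in place of oxan-2-yl on a saturated chain carbon bound to an amine nitrogen in a ring. Among the measured compounds shown here, with no single-change step in this set to lean on, the expected step of a 1.3-fold lower number from compound 1 to compound 4 (0.12 log units; within the scatter) is small and within the usual scatter. Compound 4 is therefore estimated at 90 nM, with a likely range from 35 nM to 250 nM in this assay.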

Compound 4, half-maximal inhibitory concentration: 60 nM
For compound 4 the middle estimate is 1.5-fold (0.18 log units) above the measured one, within the range that was stated.
By their numbers in this assay, from the lowest: compounds 2 and 3 (each within the scatter of the next); then compounds 4 and 1 (each within the scatter of the next).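

In this assay, oxolan-3-yl in place of oxan-2-yl on a saturated chain carbon bound to an amine nitrogen in a ring gives a 2.0-fold lower number from compound 1 to compound 4 (0.30 log units; within the scatter). This first single-place comparison shows that, on the core of compound 1, a five-membered ring can replace a six-membered one here without a change beyond the scatter. Nothing given here bears on why. Going by these compounds, it remains open whether a carboxylic acid or a primary amine at this place would also stay within the scatter. On these data alone, whether the same exchange behaves alike with other aryl groups also remains open.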